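Bis-arylidene cyclohexanone cytotoxicity: toward a hydroxy-methoxy analogue

The compounds below may be only part of what the source reports. "The series", "measured", "known", "first", "only" and "open" are said of these compounds alone.

Measured so far:
- compound 1, `COc1cccc(/C=C2\CCC/C(=C\c3ccccc3Br)C2=O)c1OC`: 12100 nM
- compound 2, `COc1ccc(/C=C2\CCC/C(=C\c3cccc(Br)c3)C2=O)cc1OC`: 4200 nM

In a functional assay on SW-620 cells (Homo sapiens) for cytotoxicity, read by MTT assay, with a stated time of 72 h (on this read-out lower numbers stand for stronger inhibition and higher numbers for weaker inhibition), compound 2 gives 4200 nM, the lowest of the two numbers; its nearest neighbour, compound 1, gives 12100 nM, a gap beyond the scatter. Compound 3, `COc1cc(/C=C2\CCC/C(=C\c3ccc(OC)c(OC)c3)C2=O)ccc1O`, has not been measured. The change from compound 2 is 4-hydroxy-3-methoxyphenyl in place of 3-bromophenyl on a double-bonded chain carbon bound to a double-bonded ring carbon. Among the measured compounds shown here, no comparable step between measured compounds exists, so the size and direction of the step in this assay cannot be read from the data. For compound 3 a step of a 1.3-fold higher number from compound 2 to compound 3 (0.12 log units; within the scatter) is expected, roughly within the scatter, so compound 3 is estimated at 5500 nM, ranging from 1800 nM to 17000 nM.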

Compound 3, half-maximal inhibitory concentration: 4500 nM
Compound 3: middle estimate off by 1.2-fold (0.09 log units), on the high side; the range from low to high includes it.
By their numbers in this assay, from the lowest: compounds 2 and 3 (each within the scatter of the next); then compound 1.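

In this assay, 4-hydroxy-3-methoxyphenyl in place of 3-bromophenyl on a double-bonded chain carbon bound to a double-bonded ring carbon gives a 1.1-fold higher number from compound 2 to compound 3 (0.03 log units; within the scatter), so in this one pair the swap leaves the number within the scatter. At this place, a group with 1 hydrogen-bond donor and 2 hydrogen-bond acceptors therefore reads the same as one with neither. No available evidence explains this result.

On these data alone, whether the hydroxy or the methoxy group matters on its own remains open. So does the reading of an amine or a carboxylic acid at this place.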